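Inverting One Stereocentre on a Peracetylated Sugar

The source may hold more compounds than are shown below. What is called first, only, known or untested is meant among the compounds shown, and "the series" means these compounds.

In a functional assay on HT-29 cells (Homo sapiens) for cytotoxicity, read by resazurin assay, with a stated time of 48 h (on this read-out higher numbers stand for weaker inhibition and lower numbers for stronger inhibition), compound 2, `CC(=O)OC[C@H]1O[C@@H](n2[se]c3ccccc3c2=O)[C@H](OC(C)=O)[C@@H](OC(C)=O)[C@@H]1OC(C)=O`, gives 11900 nM. For the measured compounds named here, of the two numbers measured so far, compound 2 has the highest; its nearest neighbour is compound 1, `CC(=O)O[C@@H]1[C@@H](OC(C)=O)[C@H](OC(C)=O)CO[C@H]1n1[se]c2ccccc2c1=O`, which gives 7300 nM. Going by the values given here, the single measured step between them, a 1.6-fold higher number from compound 1 to compound 2 (0.21 log units; within the scatter), lies within the scatter and concerns added substitution on a saturated ring carbon rather than any change of configuration.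

Compound 3, `CC(=O)OC[C@H]1O[C@@H](n2[se]c3ccccc3c2=O)[C@H](OC(C)=O)[C@@H](OC(C)=O)[C@H]1OC(C)=O`, has not yet been measured. the two compounds have the same atoms and bonds and differ only in configuration as drawn: 1 of 5 stereo elements differ; a stereocentre at a saturated ring carbon is drawn R in compound 2 and S in compound 3

Among the compounds with values here, no measured step addresses an inversion of configuration directly, because the only available step, a 1.6-fold higher number from compound 1 to compound 2 (0.21 log units; within the scatter), introduces an acetoxymethyl group without touching a stereocentre. Within the data shown here, the closeness of compound 1 at 7300 nM to compound 2 shows that this sugar portion has so far accepted alteration without a step beyond the scatter, though only two compounds support that observation. The step of no change at the digits printed from compound 2 to compound 3 (within the scatter) is therefore expected to remain within the scatter. For compound 3 the estimate is 11900 nM, with an expected range from 5000 nM to 28000 nM.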

Compound 3, half-maximal inhibitory concentration: 19300 nM
Beside the measured number, compound 3's estimate is 1.6-fold (0.21 log units) below it; the measured number falls inside the stated range.
By their numbers in this assay, from the lowest: compounds 1, 2 and 3 (each within the scatter of the next, the first and the last beyond it).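

In this assay, the inversion gives the first direct reading of configuration among these compounds, and the step, a 1.6-fold higher number from compound 2 to compound 3 (0.21 log units; within the scatter), stays within the scatter. The earlier step concerned only an added acetoxymethyl group, so it said nothing about the arrangement at a saturated ring carbon, whereas this comparison involves no change of atoms or bonds, and its structural basis is simple: the fact that compounds 2 and 3 differ only in the configuration as drawn. At this one ring carbon, then, drawing the stereocentre as R or as S gives no difference that this assay can separate from repeated-measurement scatter, at least with every other acetoxy group and the shared core held as drawn.

The compounds shown leave open whether inverting any of the other stereo elements, including the ring carbon that carries the shared core, would be equally silent in this assay. They also leave open whether this tolerance of either configuration would persist if a free hydroxyl, an amine or a longer chain stood at this ring carbon in place of the acetoxy group.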